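The compounds below may be only part of what the source reports. "The series", "measured", "known", "first", "only" and "open" are said of these compounds alone.

Three measured compounds share one core and differ only in the aryl group hung from a saturated chain carbon bound to an amine nitrogen. Compound 1 `O=S(=O)(NCCNCc1ccc(-c2ccccc2)cc1)c1cc(C(F)(F)F)cc(C(F)(F)F)c1` in a functional assay on BXPC-3 cells (Homo sapiens) for inhibition, read by MTT assay, with a stated time of 72 h (a higher number here means a weaker inhibitor of growth, a lower number a stronger inhibitor of growth), gives 1600 nM. Compound 2 `O=S(=O)(NCCCNCc1ccc(Cl)c(Cl)c1)c1cc(C(F)(F)F)cc(C(F)(F)F)c1` in this assay gives 1400 nM, and compound 3 `O=S(=O)(NCCCNCC1COc2ccccc2O1)c1cc(C(F)(F)F)cc(C(F)(F)F)c1` in this assay gives 1200 nM. On these numbers compound 2 holds the second highest of the three values, but its distance to compound 1 and its distance to compound 3 both lie within the scatter, so the three cannot be ranked.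

The unmeasured compound 4 `O=S(=O)(NCCCNCc1cccc2ccccc12)c1cc(C(F)(F)F)cc(C(F)(F)F)c1` differs from compound 2 in this way: naphthalen-1-yl in place of 3,4-dichlorophenyl on a saturated chain carbon bound to an amine nitrogen. Among the measured compounds shown here, one measured step bears on this change: a 1.2-fold lower number from compound 2 to compound 3 (0.07 log units; within the scatter), where a different ring system replaced the same 3,4-dichlorophenyl at the same place without moving the number beyond the scatter. Compound 1 and compound 2 differ in two places at once, so their values show only that another aryl on a shorter chain also lands near the same number.

For the measured compounds named here, with the one relevant step flat, compound 4 is expected to stay close to compound 2, the step of no change at the digits printed from compound 2 to compound 4 (within the scatter) being estimated as lying within the scatter. The estimated value for compound 4 in this assay is therefore 1400 nM, with a range from 600 nM to 3500 nM.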

Compound 4, concentration for 50% growth inhibition: 2700 nM
Compound 4: middle estimate off by 1.9-fold (0.29 log units), on the low side; the measured number falls inside the stated range.
By their numbers in this assay, from the lowest: compounds 3, 2, 1 and 4 (each within the scatter of the next, the first and the last beyond it).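

In this assay, putting the two-ringed naphthalen-1-yl in place of 3,4-dichlorophenyl gives a 1.9-fold higher number from compound 2 to compound 4 (0.29 log units; within the scatter), so even this change at the saturated chain carbon bound to an amine nitrogen does not separate the two compounds beyond the usual scatter. Among the compounds shown here, the comparison with the third ring system is what adds something new, as naphthalen-1-yl in place of 2,3-dihydro-1,4-benzodioxin-2-yl gives a 2.3-fold higher number from compound 3 to compound 4 (0.35 log units; beyond the scatter), the first step at this position to pass beyond the scatter, though only modestly. The groups at this position can therefore no longer all be treated as equivalent, even though compound 2 stays within the scatter of both compound 3 and compound 4, and nothing available here accounts for the gap.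

As far as these compounds go, it remains open whether this modest gap would widen or vanish with other groups at the same place, such as naphthalen-2-yl, a pyridine ring or a saturated cyclohexyl ring. From the compounds shown here alone, it is also open how a longer chain would change the number with the aryl group held fixed, since the shorter chain of compound 1 comes with a second difference.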